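Ester in place of amide: expected effect on receptor binding

The compounds below may be only part of what the source reports. "The series", "measured", "known", "first", "only" and "open" are said of these compounds alone.

Measured compounds:
compound 1 `CC1=C(C(=O)CC(C)C)C(c2ccco2)NC(=O)N1`: 16%
compound 2 `CCNC(=O)C1=C(C)NC(=O)NC1c1ccco1`: 2%
compound 3 `CC1=C(c2ncc(C)o2)C(c2ccco2)NC(=O)N1`: 27%

Three compounds sharing a core were measured in an assay on membranes from CHO cells for displacement of a labelled ligand from adenosine receptor A1 (Homo sapiens), read by scintillation counting, with a stated time of 60 min, tested at 1 uM; on this read-out higher numbers stand for more inhibition at the one concentration tested (going by the name of the read-out) and lower numbers for less inhibition. Compound 2 stands lowest of the three with 2%; the others lie beyond the scatter above it, as a number 14 percentage points lower from compound 1 to compound 2 (beyond the scatter) and a number 25 percentage points higher from compound 2 to compound 3 (beyond the scatter) show. The unmeasured compound 4 `CCC(CC)OC(=O)C1=C(C)NC(=O)NC1c1ccco1` differs from compound 2 by (pentan-3-yl)oxy in place of ethylamino on a carbonyl carbon. Going by the values given here, the only measured step that touches the same carbonyl carbon is a number 14 percentage points lower from compound 1 to compound 2 (beyond the scatter), where ethylamino replaced isobutyl and the read-out fell modestly. Compound 4 moves away from ethylamino again, though to an alkoxy group rather than a carbon chain, so the analogy is loose. The steps involving compound 3 change a different part of the molecule and bear only indirectly. A modest rise is therefore expected, roughly that earlier fall in reverse: a number 12 percentage points higher from compound 2 to compound 4 (beyond the scatter). Compound 4 is estimated at 14%, within 0% to 30%.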

Compound 4, a percentage reported as inhibition, at one concentration (the size of the read-out at that concentration, not a potency): 2%
The estimate for compound 4 lay 12 percentage points above the measured number, and the stated range covers the measured number.
By their numbers in this assay, from the lowest: compounds 2 and 4 (each within the scatter of the next); then compound 1; then compound 3.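

In this assay, the step to (pentan-3-yl)oxy on the carbonyl carbon gives no change at the digits printed from compound 2 to compound 4 (within the scatter), so compounds 2 and 4 cannot be told apart even though the entering group has 6 heavy atoms and no hydrogen-bond donor, while ethylamino has 3 heavy atoms and one such donor. Going by these compounds alone, the other new step, a number 14 percentage points lower from compound 1 to compound 4 (beyond the scatter), matches in size the earlier step from isobutyl to ethylamino, leaving isobutyl as the only one of the three groups on this carbonyl carbon to give a number beyond the scatter of the others. Nothing available explains these numbers.

As far as these compounds go, whether methoxy, a free carboxylic acid or a longer carbon chain on this carbonyl carbon would stand with compound 1 or with compounds 2 and 4 remains open. So does whether (pentan-3-yl)oxy would give the same result alongside a ring group other than the one these compounds carry.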